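The compounds below may be only part of what the source reports. "The series", "measured", "known", "first", "only" and "open" are said of these compounds alone.

In a functional assay on MCF7 cells (Homo sapiens) for antiproliferative activity, read by MTT assay, with a stated time of 48 h (a higher number here means a weaker inhibitor, a lower number a stronger inhibitor), compound 1 (`Clc1ccc(NCc2cn(-c3ccccc3)nc2-c2ccc(Cl)cc2)cc1`) gives 2280 nM, compound 2 (`Cc1ccc(NCc2cn(-c3ccccc3)nc2-c2ccc(Br)cc2)cc1`) gives 5380 nM and compound 3 (`COc1ccc(-c2nn(-c3ccccc3)cc2CNc2ccc(Cl)cc2)cc1`) gives 6250 nM. Compound 3 thus sits at the upper end of these numbers together with compound 2, the two lying within the scatter of each other, while compound 1 is the furthest from it.

Compound 4 (`Clc1ccc(NCc2cn(-c3ccccc3)nc2-c2ccc(Br)cc2)cc1`) departs from compound 3 in one place, with bromo in place of methoxy on an aromatic carbon. Going by the values given here, one measured step bears on this change, a 2.7-fold higher number from compound 1 to compound 3 (0.44 log units; beyond the scatter), a modest shift beyond the scatter for methoxy in place of chloro on an aromatic carbon. Among the compounds with values here, no measured step involves bromo directly, so that step serves only as an analogy, read in reverse. Removing the methoxy is therefore expected to give a modest move towards a lower number in this assay. The expected change is a 2.4-fold lower number from compound 3 to compound 4 (0.38 log units; beyond the scatter). Compound 4 is estimated at 2600 nM, with an expected range from 1200 nM to 5500 nM.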

Compound 4, half-maximal inhibitory concentration: 4150 nM
Beside the measured number, compound 4's estimate is 1.6-fold (0.20 log units) below it, and the stated range covers the measured number.
By their numbers in this assay, from the lowest: compounds 1, 4, 2 and 3 (each within the scatter of the next, the first and the last beyond it).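

In this assay bromo in place of methoxy gives a 1.5-fold lower number from compound 3 to compound 4 (0.18 log units; within the scatter) and bromo in place of chloro on the same aromatic carbon gives a 1.8-fold higher number from compound 1 to compound 4 (0.26 log units; within the scatter) while methoxy in place of chloro gives a 2.7-fold higher number from compound 1 to compound 3 (0.44 log units; beyond the scatter) so bromo is separated from neither group, although those two are separated from each other. At the second varied place, chloro in place of methyl on an aromatic carbon gives a 1.3-fold lower number from compound 2 to compound 4 (0.11 log units; within the scatter) and this single pair shows no separation there either. Nothing measured accounts for these results.

The compounds shown leave open whether an amine or a carboxylic acid on this aromatic carbon would give a step beyond the scatter. They also leave open how a longer chain would compare with methyl and chloro at the second place.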